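The source may hold more compounds than are shown below. What is called first, only, known or untested is meant among the compounds shown, and "the series" means these compounds.

Measured so far in an assay on isolated protein for inhibition of MAP kinase-activated protein kinase 2 (Homo sapiens), read by mobility shift assay, tested at 30 uM; a higher number here means more inhibition at the concentration tested (going by the name of the read-out), a lower number less inhibition:

compound 1, `Cc1cc2c(c(N)nn2C)c(=O)[nH]1`, 29%
compound 2, `Cn1nc(N)c2c(=O)[nH]c(-c3ccccc3)cc21`, 37%
compound 3, `COCCNc1nc(C)cc2c1c(N)nn2C`, 6%

Compound 1 and compound 2 share a core and differ in one place: phenyl in place of methyl on an aromatic carbon. In this assay that change gave a step of a number 8 percentage points higher from compound 1 to compound 2 (within the scatter). Compound 3 has a different core, and how its core differs from that of compound 1 is not broken down here. Its number is the lowest of the three, lying beyond the usual scatter from both compound 1 and compound 2.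

Compound 4, `COCCNc1nc(-c2ccccc2)cc2c1c(N)nn2C`, has not yet been measured. It differs from compound 3 in one place: phenyl in place of methyl on an aromatic carbon. This is the same kind of change as that between compound 1 and compound 2, though the surroundings differ: in compound 1 the site is meta to a group of 1 heavy atom, whereas in compound 3 it is meta to a (2-methoxyethyl)amino group (5 heavy atoms). Resting on the earlier step of a number 8 percentage points higher from compound 1 to compound 2 (within the scatter), the expected step is a number 8 percentage points higher from compound 3 to compound 4 (within the scatter). Compound 4 is therefore estimated at 14%, with a likely range from 0% to 30%.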

Compound 4, a percentage reported as inhibition, at one concentration (the size of the read-out at that concentration, not a potency): 2%
Beside the measured number, compound 4's estimate is 12 percentage points above it, within the range that was stated.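

In this assay, phenyl in place of methyl on the aromatic carbon gave a number 4 percentage points lower from compound 3 to compound 4 (within the scatter), and the comparison with the earlier step reads: the same change on two cores in this assay, a number 8 percentage points higher (within the scatter) from compound 1 to compound 2 and a number 4 percentage points lower (within the scatter) from compound 3 to compound 4, 12 percentage points apart, within the scatter of two such steps. On these two cores, then, the change carries over in the plain sense that neither step stands out from ordinary repeat variation, and the two steps cannot be told apart. Going by these compounds alone, this does not show that the change is without effect in general or that the two cores respond to it identically, since there are only two pairs, each read at a single concentration, and a small real shift could lie hidden in the scatter.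

Going by these compounds, what an amine or a carboxylic acid would do on that same aromatic carbon remains open. So does whether a longer chain, or a plain amine, in place of the (2-methoxyethyl)amino group would move the number on the core of compound 3.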